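The compounds below may be only part of what the source reports. "The series", "measured", "known", "first", "only" and "open" are said of these compounds alone.

Compound 2 `CN(C)CCn1cnnc1-c1cc(Oc2ccc(NC(=O)N/N=C/c3ccc(O)c(F)c3)cc2F)ccn1` holds the higher of the two numbers seen so far in a functional assay on A549 cells (Homo sapiens) for cytotoxicity, read by MTT assay, with a stated time of 72 h; on this read-out higher numbers stand for weaker inhibition and lower numbers for stronger inhibition: compound 2 gives 13400 nM, while compound 1 `COc1ccc(OC)c(/C=N/NC(=O)Nc2ccc(Oc3ccnc(-c4nncn4CCN(C)C)c3)c(F)c2)c1` gives 1950 nM. Compound 3 `CN(C)CCn1cnnc1-c1cc(Oc2ccc(NC(=O)N/N=C/c3c(O)ccc4ccccc34)cc2F)ccn1` differs from compound 2 in one place: 2-hydroxynaphthalen-1-yl in place of 3-fluoro-4-hydroxyphenyl on a carbon with a double bond to nitrogen. Within the data shown here, the only measured step that bears on this swap is a 6.9-fold higher number from compound 1 to compound 2 (0.84 log units; beyond the scatter), where the same carbon carried the change, so this position can shift the number well beyond the scatter. One step cannot settle the direction, but a moderate move toward a lower number is expected, a 2.2-fold lower number from compound 2 to compound 3 (0.35 log units; beyond the scatter). The estimate for compound 3 is therefore 6000 nM, with a range from 1500 nM to 25000 nM.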

Compound 3, half-maximal inhibitory concentration: 880 nM
The estimate for compound 3 lay 6.8-fold (0.83 log units) above the measured number; the measured number lies below the stated range.
By their numbers in this assay, from the lowest: compound 3; then compound 1; then compound 2.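

On this carbon, the size of the aryl group's effect is larger than the earlier step showed: 2-hydroxynaphthalen-1-yl gives a 15-fold lower number from compound 2 to compound 3 (1.18 log units; beyond the scatter) and, against the 2,5-dimethoxyphenyl group, a 2.2-fold lower number from compound 1 to compound 3 (0.35 log units; beyond the scatter) as well. Of the three groups seen here, the one with two aromatic rings therefore gives the lowest number, and both of its steps lie beyond the scatter. Nothing available here accounts for this shift.

Still open, on these data alone, is whether the second ring alone drives the change or whether the hydroxyl is needed too. A plain naphthalen-1-yl group, or one carrying a methoxy or an amine instead of the hydroxyl, would separate these two parts.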